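Swapping methoxy for methylsulfanyl in a compound at the limit

The source may report more compounds than this note shows. Statements on the series, on what has been measured and on what is new or still open speak of the compounds shown alone.

Values in a functional assay on HCT-116 cells (Homo sapiens), read by MTT assay, with a stated time of 72 h (a higher number here means a weaker inhibitor, a lower number a stronger inhibitor), as measured so far:
Compound 1 `COc1ncnc2c1c(-c1ccccc1)cn2[C@@H]1O[C@H](CO)[C@@H](O)[C@H]1O` gives > 20000 nM as a limit
Compound 2 `C#Cc1cn([C@@H]2O[C@H](CO)[C@@H](O)[C@H]2O)c2ncnc(OC)c12` gives 4060 nM
Compound 3 `CSc1ncnc2c1c(-c1ccsc1)cn2[C@@H]1O[C@H](CO)[C@@H](O)[C@H]1O` gives > 20000 nM as a limit

Compound 1 has only a limit and no number, and its place is the limit of > 20000 nM in this assay, at which 2 of the 3 values shown sit, in the series. Compound 4 `CSc1ncnc2c1c(-c1ccccc1)cn2[C@@H]1O[C@H](CO)[C@@H](O)[C@H]1O` keeps the core of compound 1 and changes one group: methylsulfanyl in place of methoxy on an aromatic carbon with methylsulfanyl in place of methoxy on an aromatic carbon, next to the ring nitrogen. Within the data shown here, the only measured step, an at least 4.9-fold lower number from compound 1 to compound 2 (0.69 log units; beyond the scatter), replaces the phenyl group and leaves methoxy untouched, so it bears on the change only indirectly. It does show that the phenyl group, not methoxy, was the change that moved the value. Compound 3 also carries methylsulfanyl, and its > 20000 nM is a limit, which is the ground for expecting no gain from this group. The expected step is a number no higher from compound 1 to compound 4 (the limit leaves the size open), with no shift beyond the scatter in either direction. Compound 4 is expected at 20000 nM in this assay, with an estimated range from 9000 nM to 40000 nM, and most likely only a limit will be reported.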

Compound 4, half-maximal inhibitory concentration: > 20000 nM
Compound 4 ended at the assay's limit; the forecaster's own chance of this, stated with the estimate: 75%; the middle value lies on the limit itself.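

In this assay compound 4 gives > 20000 nM, which is a limit and not a number. The steps to compound 4 from compound 1 and from compound 3 join two limits and cannot be read. The compounds shown leave open whether methylsulfanyl in place of methoxy changes the value at all.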